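A few compounds are considered here, and "the series" means these few. Any claim that something is new, unique, unknown or untested is made for them only; others in the source may bear on it.

Compound 2, `CC[C@H](C)[C@H](N)CN(C(=O)[C@@H]1C[C@H]1c1ccccn1)c1ccc(-c2ccccc2)cc1`, stands lowest of the two numbers in hand. In a functional assay for agonist activity at G protein-coupled receptor 88 (Homo sapiens), read by HTRF and cAMP accumulation (a lower number here means that less compound is needed, a higher number that more compound is needed for the effect), compound 2 gives 130 nM, while compound 1, `CC[C@H](C)[C@H](N)CN(C(=O)[C@@H]1C[C@H]1c1ccc(F)cc1)c1ccc(-c2ccccc2)cc1`, gives 600 nM in this assay. Among the compounds with values here, the one measured step, a 4.6-fold lower number from compound 1 to compound 2 (0.66 log units; beyond the scatter), therefore separates the two, and compound 2 has no closer neighbour than compound 1.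

Compound 3, `CC[C@H](C)[C@H](N)CN(C(=O)[C@@H]1C[C@H]1c1cncnc1)c1ccc(-c2ccccc2)cc1`, is the next compound to be measured. It differs from compound 2 in one place: pyrimidin-5-yl in place of pyridin-2-yl on a saturated ring carbon. Within the data shown here, the only step that bears on this position is the one from compound 1 to compound 2, which changed a 4-fluorophenyl into a pyridin-2-yl on the same saturated ring carbon and gave a modest move beyond the scatter. Among the measured compounds shown here, nothing measured here tells how a pyrimidin-5-yl behaves at that place, so the single step gives no direction for it. The step from compound 2 to compound 3 in this assay is estimated as a 1.9-fold higher number from compound 2 to compound 3 (0.28 log units; within the scatter), which is small against a wide range. For compound 3 the expected value in this assay is 250 nM, with an estimated range from 80 nM to 800 nM.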

Compound 3, half-maximal effective concentration: 19000 nM
For compound 3 the middle estimate is 76-fold (1.88 log units) below the measured one, and the stated range ends below it.
By their numbers in this assay, from the lowest: compound 2; then compound 1; then compound 3.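

In this assay, within the data shown here, this place on the saturated ring carbon proves far less forgiving than the first pair of compounds suggested: the change brings a 150-fold higher number from compound 2 to compound 3 (2.16 log units; beyond the scatter), even though the pyrimidin-5-yl matches the leaving pyridin-2-yl in its count of heavy atoms and is likewise one six-membered aromatic ring. Among these compounds, the rise is not specific to the comparison with pyridin-2-yl, for the other route gives a 32-fold higher number from compound 1 to compound 3 (1.50 log units; beyond the scatter), and both steps are large, whereas the only earlier change at this place, a 4.6-fold lower number from compound 1 to compound 2 (0.66 log units; beyond the scatter), was modest. Nothing measured here explains why the pyrimidin-5-yl stands so far from the other two groups.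

The compounds shown cannot separate the effect of the second ring nitrogen from that of the different point of attachment, since the two differ together between compound 2 and compound 3. A pyridin-3-yl or a pyrimidin-2-yl on the same saturated ring carbon would pull those two changes apart, and a pyrimidin-5-yl carrying a methyl or an amine would show whether the ring can be recovered at all.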